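Notes on compound 3 and the step to compound 4

A few compounds are considered here, and "the series" means these few. Any claim that something is new, unique, unknown or untested is made for them only; others in the source may bear on it.

Compound 1 `CCc1ccc2oc(CSc3nnc(CNc4ccccc4)n3CC)nc2c1`, compound 2 `CCn1c(CNc2ccccc2)nnc1SCC(=O)Nc1ccccc1` and compound 3 `CCn1c(CNc2ccccc2)nnc1SCC(=O)Nc1ccc(Cl)cc1` share one core. In an assay on isolated protein for inhibition of long-chain fatty acid transport protein 1 (Homo sapiens) (on this read-out higher numbers stand for weaker inhibition and lower numbers for stronger inhibition), compound 1 gives only the limit > 1000 nM. In this assay compound 2 likewise gives only the limit > 1000 nM. Compound 3 also gives only the limit > 1000 nM. All three therefore sit at the limit of > 1000 nM in this assay, at which 3 of the 3 values shown sit, and the step that the two limits leave unreadable from compound 2 to compound 3 is unreadable. Compound 4 `CCn1c(CNc2ccccc2)nnc1SCC(=O)Nc1ccc(C(=O)OC)cc1` differs from compound 3 by methoxycarbonyl in place of chloro on an aromatic carbon, para to a large group. Among the measured compounds shown here, no measured step in this assay bears on this change, and no number exists to move from. Compound 4 is therefore expected to stay near the limit, estimated at 2000 nM with a range of 700 nM to 10000 nM. The expected step that the limit leaves unreadable from compound 3 to compound 4 is none beyond the scatter.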

Compound 4, half-maximal inhibitory concentration: 540 nM
For compound 4 the middle estimate is 3.7-fold (0.57 log units) above the measured one, and the stated range ends above it.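

In this assay, among the compounds shown here, the 4-(methoxycarbonyl)phenyl group of compound 4 gives the only reading so far that is a number rather than a limit: the limit of > 1000 nM in this assay, at which 3 of the 4 values shown sit. Methoxycarbonyl in place of chloro gives an at least 1.8-fold lower number from compound 3 to compound 4 (0.26 log units; that floor lies within the scatter), and in place of hydrogen it gives an at least 1.8-fold lower number from compound 2 to compound 4 (0.26 log units; that floor lies within the scatter). Going by these compounds, both are floors, so the true size of each step stays open, and the step between the two limits cannot be read.

The compounds shown leave open how a carboxylic acid or a primary amide would read at this place. They also leave open whether methoxycarbonyl would give a number elsewhere on the shared core.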